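From a 4-fluorophenyl ether to a carbamate

The source may report more compounds than this note shows. Statements on the series, on what has been measured and on what is new or still open speak of the compounds shown alone.

Of the compounds shown here, three with a shared core have been measured in a functional assay on V79-379A cells (Cricetulus griseus) for cytotoxicity, read by MTT assay, in the presence of a further agent that is not named here (a lower number here means a stronger inhibitor, a higher number a weaker inhibitor), and they differ in the group on one oxygen. Compound 1 (`COC1=CC(=O)c2c(c(COC(C)=O)c(C)n2C)C1=O`) carries acetyl there and gives 27000 nM in this test. Compound 2 (`COC1=CC(=O)c2c(c(COc3ccccc3)c(C)n2C)C1=O`) carries phenyl and gives 12000 nM in this test. Compound 3 (`COC1=CC(=O)c2c(c(COc3ccc(F)cc3)c(C)n2C)C1=O`) carries 4-fluorophenyl and gives 31000 nM in this test. That places compound 3 level with compound 1 (a 1.1-fold higher number from compound 1 to compound 3 (0.06 log units; within the scatter)) and above compound 2 (a 2.6-fold higher number from compound 2 to compound 3 (0.41 log units; beyond the scatter)).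

Compound 4 (`COC1=CC(=O)c2c(c(COC(N)=O)c(C)n2C)C1=O`) has carbamoyl in place of 4-fluorophenyl on an oxygen on a saturated carbon. Within the data shown here, no measured compound carries carbamoyl, so the evidence is indirect. The closest model is compound 1 (27000 nM), whose acetyl, like carbamoyl, has no ring. The other two steps are both modest (a 2.3-fold lower number from compound 1 to compound 2 (0.35 log units; beyond the scatter); a 2.6-fold higher number from compound 2 to compound 3 (0.41 log units; beyond the scatter)). So changes in this group have moved the number only a little, and a small step toward a lower number is expected, probably not beyond the scatter (a 1.4-fold lower number from compound 3 to compound 4 (0.15 log units; within the scatter)). The expected value for compound 4 is 22000 nM (estimated range 7000 nM to 60000 nM).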

Compound 4, half-maximal inhibitory concentration: 25000 nM
Estimate against measurement, compound 4: 1.1-fold (0.06 log units) below, within the range that was stated.
By their numbers in this assay, from the lowest: compound 2; then compounds 4, 1 and 3 (each within the scatter of the next).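

Carbamoyl on this oxygen takes out the ring of compound 3 and brings in a hydrogen-bond donor, yet in this assay the result is a 1.2-fold lower number from compound 3 to compound 4 (0.09 log units; within the scatter), and the exchange of methyl for amino on the carbonyl carbon gives a 1.1-fold lower number from compound 1 to compound 4 (0.03 log units; within the scatter), so three quite different groups now read alike. Only the plain phenyl ether stands apart, with a 2.1-fold higher number from compound 2 to compound 4 (0.32 log units; beyond the scatter), a modest step; compound 3, which also carries a ring, goes against any rule that a ring on this oxygen lowers the number. Nothing in the data given explains why these groups read alike or why compound 2 differs from them.

Still open, going by these compounds, is whether any group in this place can move the number by more than these modest steps, for example an amine, a carboxylic acid or a longer chain. On these data alone, it is also open whether the gap between compound 2 and compound 3 is special to fluoro or would recur with chloro or methoxy on the aromatic ring.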